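Sulfonamide and sulfonate ureas: cytotoxicity on breast cancer cells

The compounds below may be only part of what the source reports. "The series", "measured", "known", "first", "only" and "open" are said of these compounds alone.

Measured so far:
compound 1, `CCc1ccccc1NS(=O)(=O)c1cccc(NC(=O)NCCCCl)c1`, 43000 nM
compound 2, `CCCc1ccccc1NS(=O)(=O)c1cccc(NC(=O)NCCCCl)c1`, 18000 nM
compound 3, `CCNC(=O)Nc1cccc(S(=O)(=O)Oc2ccccc2C)c1`, 55000 nM

All three were run in a functional assay on MCF7 cells (Homo sapiens) for cytotoxicity, read by sulforhodamine B assay, with a stated time of 48 h; on this read-out lower numbers stand for stronger inhibition and higher numbers for weaker inhibition. Compound 1 gives 43000 nM and compound 2 gives 18000 nM. The change between them is methyl in place of hydrogen on a saturated chain carbon, two bonds along the chain from an aromatic carbon, and it produced a 2.4-fold lower number from compound 1 to compound 2 (0.38 log units; beyond the scatter). Compound 3 gives 55000 nM; it stands close to compound 1, within the scatter, and further from compound 2, beyond the scatter. The difference between the core of compound 3 and the core of compound 1 is not broken down here.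

Compound 4, `CCNC(=O)Nc1cccc(S(=O)(=O)Oc2ccccc2CC)c1`, is not yet measured in this assay. It differs from compound 3 by methyl in place of hydrogen on a saturated chain carbon bound to an aromatic carbon. This is the same kind of change as that from compound 1 to compound 2, but not the same: there the added methyl sat on a saturated chain carbon two bonds along the chain from an aromatic carbon, here it sits on a saturated chain carbon bound to an aromatic carbon, and the core itself differs between the two pairs.

Among the measured compounds shown here, only one earlier instance of this kind of change is available, so the expectation rests on it alone. The step from compound 3 to compound 4 is expected to be a 1.7-fold lower number from compound 3 to compound 4 (0.24 log units; within the scatter), smaller than the earlier step because a 2.4-fold lower number from compound 1 to compound 2 (0.38 log units; beyond the scatter) was seen on a different core and at a different place on the chain. Compound 4 is therefore estimated at 32000 nM in this assay, with a range from 13000 nM to 75000 nM.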

Compound 4, half-maximal inhibitory concentration: 31000 nM
Compound 4: the middle estimate sits 1.0-fold (0.01 log units) above what was measured; the measured number falls inside the stated range.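

In this assay, methyl in place of hydrogen on a saturated chain carbon bound to an aromatic carbon gives a 1.8-fold lower number from compound 3 to compound 4 (0.25 log units; within the scatter), a step that on its own does not stand clear of the usual scatter. Set beside the earlier step, this change shows no difference in size between the two cores: the same change on two cores in this assay, a 2.4-fold lower number (0.38 log units; beyond the scatter) from compound 1 to compound 2 and a 1.8-fold lower number (0.25 log units; within the scatter) from compound 3 to compound 4, 1.3-fold (0.13 log units) apart, within the scatter of two such steps. That agreement is compatible with carrying the change from one core to the other, but it rests on a single pair per core, with the added methyl at a different place on the chain in each pair, so it does not establish a rule for the series or show that the step on the core of compound 3 is a real effect.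

Still open, as far as these compounds go, is whether the same change at the same place on the chain gives a step of the same size on both cores, as the two pairs differ in both core and place. Also open, from the compounds shown here alone, is whether a chain longer than propyl, or an amine or a carboxylic acid at that place, would move the number clearly beyond the scatter on either core.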